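Oxadiazole series: ether chain in place of cyclobutyl

The source may hold more compounds than are shown below. What is called first, only, known or untested is meant among the compounds shown, and "the series" means these compounds.

Compound 1 `CC(C)c1nc(C(=O)NCC2(C)CCN(CC3CCOCC3)CC2)c2ccccn12`: 53 nM
Compound 2 `CC(C)c1nc(-c2nnc(C3CCN(CC4CCC4)CC3)o2)c2ccccn12`: 520 nM

In a functional assay on CHO cells for agonist activity at 5-hydroxytryptamine receptor 4 (Homo sapiens), read by a luciferase reporter and cAMP accumulation, with a stated time of 4 h (on this read-out higher numbers stand for an effect only at larger amounts of compound and lower numbers for an effect already at smaller amounts), compound 2 stands highest of the two numbers; compound 1 is the nearest and sits well beyond the scatter from it. Compound 3 `COCCCN1CCC(c2nnc(-c3nc(C(C)C)n4ccccc34)o2)CC1` carries 2-methoxyethyl in place of cyclobutyl on a saturated chain carbon bound to an amine nitrogen in a ring. Among the measured compounds shown here, no step of this exact kind is available among the measured compounds, so the direction rests on the change alone: an expected small move toward lower numbers, a 1.5-fold lower number from compound 2 to compound 3 (0.17 log units; within the scatter), which may well stay within the scatter. Compound 3 is therefore estimated at 350 nM in this assay, between 120 nM and 1000 nM.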

Compound 3, half-maximal effective concentration: 736 nM
Estimate against measurement, compound 3: 2.1-fold (0.32 log units) below; the range from low to high includes it.
By their numbers in this assay, from the lowest: compound 1; then compounds 2 and 3 (each within the scatter of the next).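

In this assay, the step of a 1.4-fold higher number from compound 2 to compound 3 (0.15 log units; within the scatter) lies within the scatter, so this pair gives no sign that the group matters on a saturated chain carbon bound to an amine nitrogen in a ring. Here an open chain carrying one hydrogen-bond acceptor replaces a four-membered carbon ring with no reading beyond the scatter. No supporting data bear on this result. On these data alone, whether an amine, a carboxylic acid or a longer chain at this place would give a step beyond the scatter remains open.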